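This account rests on a few compounds, and the source may have more. Where it says the series, first, only, none or still open, it means among the compounds named here.

Working notes on the series.

The shared core carries a 4-hydroxyphenyl group, a chlorophenyl group and a five-membered sulfur heterocycle. Compound 1 `Oc1ccc(-c2cc(-c3ccccn3)nc(-c3ccccc3Cl)c2)cc1` gives "not determined" (no result reported) in a functional assay on DU-145 cells (Homo sapiens) for cytotoxicity, read by CCK-8 assay and cell counting, with a stated time of 2 days (on this read-out lower numbers stand for stronger inhibition and higher numbers for weaker inhibition), so it has no result there. Compound 2 `Oc1ccc(-c2cc(-c3cccs3)nc(-c3ccccc3Cl)c2)cc1` gives 4190 nM in this assay. Compound 3 `Oc1ccc(-c2cc(-c3ccc(Cl)cc3)nc(-c3ccsc3)c2)cc1` gives 6940 nM in this assay. Compound 3 is the larger of the two recorded numbers, but its gap to compound 2 is within the usual scatter, so the two are not separated, and compound 1 adds no number.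

Compound 4 `Oc1ccc(-c2cc(-c3ccsc3)nc(-c3ccccc3Cl)c2)cc1` differs from compound 3 in one place: 2-chlorophenyl in place of 4-chlorophenyl on an aromatic carbon. The two compounds have the same atoms, joined differently. For the measured compounds named here, no step between measured compounds isolates this change. The only other compound bearing 2-chlorophenyl is compound 2, whose value 4190 nM sits within the scatter of compound 3, so no direction beyond the scatter can be drawn from the numbers shown.

The step from compound 3 to compound 4 in this assay is therefore expected to be small, a 1.3-fold lower number from compound 3 to compound 4 (0.10 log units; within the scatter), with no direction claimed beyond the scatter. Compound 4 is estimated at 5500 nM in this assay, within a range of 2200 nM to 14000 nM.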

Compound 4, half-maximal inhibitory concentration: 3890 nM
Beside the measured number, compound 4's estimate is 1.4-fold (0.15 log units) above it; measured number inside the range.
By their numbers in this assay, from the lowest: compounds 4, 2 and 3 (each within the scatter of the next).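

For the compounds shown here, compound 4 supplies the first single-place steps, linking compound 3 and compound 2 through one shared structure. With the thiophen-3-yl group held fixed, 2-chlorophenyl in place of 4-chlorophenyl on the aromatic carbon next to the ring nitrogen gives a 1.8-fold lower number from compound 3 to compound 4 (0.25 log units; within the scatter) in this assay and so does not separate the two chlorophenyl arrangements; with 2-chlorophenyl held fixed, thiophen-3-yl in place of thiophen-2-yl gives a 1.1-fold lower number from compound 2 to compound 4 (0.03 log units; within the scatter) and leaves the two thiophene attachments equally unseparated. No measured information on any property of these compounds is available to bear on these results.

Steps to compound 1 cannot be read, since compound 1 gives "not determined" (no result reported) in this assay and so provides no comparison for its group. Whether any replacement at the position next to the ring nitrogen can move the number beyond the scatter remains open, as the compounds shown cover only chlorophenyl and thiophene isomers and do not include a group such as an amine or a carboxylic acid there.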